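Inverting one stereocentre of compound 2

The source may hold more compounds than are shown below. What is called first, only, known or untested is meant among the compounds shown, and "the series" means these compounds.

- compound 1 `C/C1=C\CC[C@@]2(C)O[C@@H]2[C@H]2OC(=O)[C@@H](CN3CCCCC3)[C@@H]2C[C@H]1O`: 16000 nM
- compound 2 `C/C1=C\CC[C@@]2(C)O[C@@H]2[C@H]2OC(=O)[C@@H](CN3CCN(C)CC3)[C@@H]2C[C@H]1O`: 57000 nM
- compound 3 `COc1ccc(N2CCN(C[C@@H]3C(=O)O[C@H]4[C@H]3C[C@@H](O)/C(C)=C/CC[C@@]3(C)O[C@H]43)CC2)cc1`: 25000 nM

These three values come from a functional assay on SK-MEL-28 cells (Homo sapiens) for inhibition, read by MTT assay, with a stated time of 72 h; on this read-out lower numbers stand for stronger inhibition and higher numbers for weaker inhibition. Among them, compound 2 gives 57000 nM, the highest number of the three. The two measured steps that touch it are both modest, though beyond the scatter: a 3.6-fold higher number from compound 1 to compound 2 (0.55 log units; beyond the scatter) and a 2.3-fold lower number from compound 2 to compound 3 (0.36 log units; beyond the scatter).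

Compound 4 `C/C1=C\CC[C@@]2(C)O[C@@H]2[C@H]2OC(=O)[C@@H](CN3CCN(C)CC3)[C@@H]2C[C@@H]1O` has not yet been measured. It differs from compound 2 only in configuration as drawn: the two compounds have the same atoms and bonds and differ only in configuration as drawn: 1 of 7 stereo elements differ; a stereocentre at a saturated ring carbon is drawn R in compound 2 and S in compound 4, a stereocentre at a saturated ring carbon is drawn R in compound 2 and S in compound 4. Both measured steps exchange a group and leave every stereocentre as drawn, so neither shows directly what this inversion does. They serve only as a yardstick of size for this series. No step beyond the scatter is therefore expected in this assay, and no direction can be favoured, although the uncertainty remains wide. The expected step is a 1.1-fold lower number from compound 2 to compound 4 (0.06 log units; within the scatter). For compound 4 the estimated value is 50000 nM, within an expected range from 20000 nM to 100000 nM.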

Compound 4, half-maximal inhibitory concentration: 23000 nM
For compound 4 the middle estimate is 2.2-fold (0.34 log units) above the measured one; measured number inside the range.
By their numbers in this assay, from the lowest: compounds 1, 4 and 3 (each within the scatter of the next); then compound 2.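

In this assay, the configuration at this saturated ring carbon has a measurable effect of its own, with a 2.5-fold lower number from compound 2 to compound 4 (0.39 log units; beyond the scatter). Among the compounds shown here, the earlier steps all exchanged a group on the amine side and left every stereocentre as drawn, so this is the first reading of this position, and it is modest, like those group exchanges. The step can be attributed to the inversion alone, because no atom or bond changes: the fact that compounds 2 and 4 differ only in the configuration as drawn.

For the compounds shown here, the inversion is seen only with the 4-methylpiperazin-1-yl group, so it remains open whether it would shift the number in the same direction with the piperidin-1-yl group of compound 1 or the 4-methoxyphenyl group of compound 3. Also open, as far as these compounds go, is what a morpholin-4-yl group on the same chain carbon would give in either configuration.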